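Sulfonamide Variation on a Benzoxazole Scaffold: Hydroxy to Ethyl

The compounds below may be only part of what the source reports. "The series", "measured", "known", "first", "only" and "open" are said of these compounds alone.

Measured compounds:
compound 1 `O=S(=O)(Nc1ccc(-c2nc3ccccc3o2)cc1)c1ccc(Cl)s1` gives 31000 nM in an assay on cells for inhibition of HSP60/HSP10 (Homo sapiens), with a stated time of 60 min; on this read-out lower numbers stand for stronger inhibition and higher numbers for weaker inhibition;
compound 2 `O=S(=O)(Nc1ccc(-c2nc3ccccc3o2)cc1)c1ccc(O)cc1` gives 78000 nM in this assay.

Compound 2 holds the highest of the two numbers, with compound 1 as its nearest neighbour: a 2.5-fold higher number from compound 1 to compound 2 (0.40 log units; beyond the scatter). Compound 3 `CCc1ccc(S(=O)(=O)Nc2ccc(-c3nc4ccccc4o3)cc2)cc1` has not yet been measured in this assay. It differs from compound 2 in one place: ethyl in place of hydroxy on an aromatic carbon. Among the measured compounds shown here, the only measured step bearing on this change is the one from compound 1 to compound 2, where a group carrying no hydroxy was replaced by 4-hydroxyphenyl and the number rose modestly. The step to compound 3 takes the hydroxy away again, so a modest lowering of the number, roughly undoing that earlier rise, is expected for compound 3: a 2.2-fold lower number from compound 2 to compound 3 (0.35 log units; beyond the scatter). Compound 3 is therefore estimated at 35000 nM, with a range from 12000 nM to 100000 nM.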

Compound 3, half-maximal inhibitory concentration: > 100000 nM
Compound 3: no number, only a limit; the forecaster's own chance of this, stated with the estimate: 10%; at least 2.8-fold (0.45 log units) between middle value and limit.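

Taking the hydroxy away did not bring the number back down, and the reading for compound 3 is a limit of the assay, not a number: the limit of > 100000 nM in this assay, at which 1 of the 3 values shown sits. On the aromatic carbon itself the result is an at least 1.2-fold higher number from compound 2 to compound 3 (0.10 log units; that floor lies within the scatter), so ethyl and hydroxy at this position cannot be ranked, as the floor of that step does not clear the scatter. The wider swap on the sulfonyl sulfur is clearer, at an at least 3.2-fold higher number from compound 1 to compound 3 (0.50 log units; beyond the scatter), so 4-ethylphenyl, which carries no hydroxy, also gives a higher number than 5-chlorothiophen-2-yl.

As far as these compounds go, the true size of the step from hydroxy to ethyl remains open. So does what an amine, a carboxylic acid or a longer chain in this same place would give in this assay.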